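Triazole Nitrogen: From Bromophenyl to Dimethylphenyl

The source may report more compounds than this note shows. Statements on the series, on what has been measured and on what is new or still open speak of the compounds shown alone.

Among the measured compounds shown here, in a functional assay on MCF7 cells (Homo sapiens) for antiproliferative activity, read by MTT assay, with a stated time of 48 h (a higher number here means a weaker inhibitor, a lower number a stronger inhibitor), compound 3 `N#CC1=C(N)Oc2c(N)cc3nc4ccccc4nc3c2C12C(=O)N(Cc1cnnn1-c1ccccc1Br)c1ccccc12` gives 30700 nM, the only number among the three measured compounds. Compound 1 `COc1ccc(-n2nncc2CN2C(=O)C3(C(C#N)=C(N)Oc4c3c3nc5ccccc5nc3c3ccccc43)c3ccccc32)cc1` reaches only the limit > 50000 nM. Compound 2 `Cc1cccc(-n2nncc2CN2C(=O)C3(C(C#N)=C(N)Oc4c(N)cc5nc6ccccc6nc5c43)c3ccccc32)c1` likewise stops at the limit > 50000 nM. For the measured compounds named here, the single measured step, an at least 1.6-fold lower number from compound 2 to compound 3 (0.21 log units; that floor lies within the scatter), has a floor inside the scatter, and the limit of > 50000 nM in this assay, at which 2 of the 3 values shown sit, is where most values end. Compound 4 `Cc1ccc(-n2nncc2CN2C(=O)C3(C(C#N)=C(N)Oc4c(N)cc5nc6ccccc6nc5c43)c3ccccc32)cc1C` differs from compound 3 by 3,4-dimethylphenyl in place of 2-bromophenyl on an aromatic nitrogen. Because the step of an at least 1.6-fold lower number from compound 2 to compound 3 (0.21 log units; that floor lies within the scatter) was no larger than its floor, the reverse-like move in compound 4 is expected to give a step of a 1.5-fold higher number from compound 3 to compound 4 (0.17 log units; within the scatter), upward and modest. Compound 4 is estimated at 45000 nM in this assay, between 20000 nM and 100000 nM, with a fair chance that only a limit is reported.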

Compound 4, half-maximal inhibitory concentration: > 50000 nM
Compound 4: no number, only a limit; the forecaster's own chance of this, stated with the estimate: 50%; middle value at least 1.1-fold (0.04 log units) from the limit.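

In this assay compound 4 gives only a limit of the assay, not a number, so 3,4-dimethylphenyl, like 3-methylphenyl in compound 2, yields no readable value at this position. Putting 3,4-dimethylphenyl in place of 2-bromophenyl gives an at least 1.6-fold higher number from compound 3 to compound 4 (0.21 log units; that floor lies within the scatter), while the step that adds the methyl cannot be read. Only compound 3 keeps a number, and the others end at one ceiling: the limit of > 50000 nM in this assay, at which 3 of the 4 values shown sit.

From the compounds shown here alone, whether any group on this aromatic nitrogen brings the number clearly under that limit stays open. How an aminophenyl, a carboxyphenyl or a benzyl group would read here is also unknown.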